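The compounds below may be only part of what the source reports. "The series", "measured", "known", "first", "only" and "open" are said of these compounds alone.

Compound 1 `CCOC(=O)c1c(-c2ccccc2)[nH]c2cc(OC)ccc2c1=O`: > 21500 nM
Compound 2 `CCOC(=O)c1c(-c2cccc(OCc3ccccc3)c2)[nH]c2cc(OC)ccc2c1=O`: > 21500 nM

Both compounds were tested in an ADME assay on Raji cells (Homo sapiens) for cytotoxicity, read by luminescence, with a stated time of 72 h; on this read-out lower numbers stand for an effect already at smaller amounts and higher numbers for an effect only at larger amounts of compound. Compound 2 stands at > 21500 nM, which is a limit of the assay and not a number. For the measured compounds named here, the same is true of compound 1, so the whole series so far rests on one limit: the limit of > 21500 nM in this assay, at which 2 of the 2 values shown sit.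

Compound 3 `CCOC(=O)c1c(-c2cccc(Cl)c2)[nH]c2cc(OC)ccc2c1=O` carries chloro in place of benzyloxy on an aromatic carbon, (chloro in place of benzyloxy on an aromatic carbon). Going by the values given here, the one measured step that bears on this is a step that the two limits leave unreadable from compound 1 to compound 2, where benzyloxy replaced hydrogen on an aromatic carbon. That step gives no size to carry over, so no change beyond the scatter is expected. The expected step is a number no higher from compound 2 to compound 3 (the limit leaves the size open). Compound 3 is expected to stay near the limit, with an estimate of 21500 nM and an estimated range of 10000 nM to 40000 nM.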

Compound 3, half-maximal effective concentration: > 21500 nM
Compound 3: no number, only a limit (the forecaster's own chance of this, stated with the estimate: 85%); the middle value sits exactly at the limit.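

Compound 3, like compound 1 and compound 2, gives no number in this assay, so no step among these three compounds can be read, and all of them stop at the same edge: the limit of > 21500 nM in this assay, at which 3 of the 3 values shown sit.

What remains open is whether any of these compounds has a measurable effect on the cells at all, and how chloro, benzyloxy and hydrogen on that aromatic carbon compare.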